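The source may hold more compounds than are shown below. What is called first, only, known or untested is meant among the compounds shown, and "the series" means these compounds.

In a functional assay on HeLa cells (Homo sapiens) for inhibition, read by MTT assay, with a stated time of 4 days (on this read-out lower numbers stand for stronger inhibition and higher numbers for weaker inhibition), the measured compounds are:
- compound 1 `COc1cc(NC(C)CCCNC(=O)NNC(=O)NCCCCCO)c2ncccc2c1`: >= 250000 nM, a limit
- compound 2 `COc1cc(NC(C)CCCNC(=O)NNC(=O)Nc2ccc(Cl)c(C(F)(F)F)c2)c2ncccc2c1`: 17000 nM

Compound 1 stands at the limit of >= 250000 nM in this assay, at which 1 of the 2 values shown sits.

Compound 3 `COc1cc(NC(C)CCCNC(=O)NN)c2ncccc2c1` has hydrogen in place of (5-hydroxypentyl)carbamoyl on an amine nitrogen. Within the data shown here, only one measured step bears on this, and only indirectly. That large step, an at least 14-fold lower number from compound 1 to compound 2 (1.16 log units; beyond the scatter), changed the same end of the molecule, but it added the 4-chloro-3-(trifluoromethyl)phenyl, which compound 3 does not carry. In this assay, a modest move towards a lower number is therefore expected, estimated as an at least 2.0-fold lower number from compound 1 to compound 3 (0.31 log units; beyond the scatter). The estimated value for compound 3 is 120000 nM, within a range of 40000 nM to 250000 nM.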

Compound 3, half-maximal inhibitory concentration: >= 250000 nM
Compound 3 was reported as a limit; the forecaster's own chance of this, stated with the estimate: 40%; middle value at least 2.0-fold (0.31 log units) away from the limit.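

No step can be read from compound 1 to compound 3, because both values are limits: the limit of >= 250000 nM in this assay, at which 2 of the 3 values shown sit. The compounds shown leave open whether losing the (5-hydroxypentyl)carbamoyl changes inhibition at all.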